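Removing the Fluoro: From Compound 2 to Compound 3

The compounds below may be only part of what the source reports. "The series", "measured", "known", "first", "only" and "open" are said of these compounds alone.

compound 1, `COc1cc(OC)cc(-n2c(-c3ccccc3)nc(C)c2C)c1`: 20.2%
compound 2, `COc1ccc(-n2c(-c3ccc(F)cc3)nc(C)c2C)cc1`: 20.2%

In a functional assay, read by spectrophotometry, with a stated time of 30 min, tested at 20 uM (a higher number here means a stronger effect of the compound at the concentration tested, a lower number a weaker effect), compound 1 gives 20.2%. In this assay compound 2 gives 20.2%. Compound 2 thus stands level with compound 1 at the digits shown, within the usual scatter, and no step between measured compounds differing in one place is known. Compound 3 `COc1ccc(-n2c(-c3ccccc3)nc(C)c2C)cc1` differs from compound 2 by hydrogen in place of fluoro on an aromatic carbon. Among the measured compounds shown here, no measured pair speaks to this change, so the step of a number 0.2 percentage points lower from compound 2 to compound 3 (within the scatter) is expected to stay within the scatter, with no clear direction. Compound 3 is estimated at 20%, with a range from 8% to 32%.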

Compound 3, a percentage reported as activity, at one concentration (the size of the read-out at that concentration, not a potency): 28.3%
Compound 3: the middle estimate sits 8.3 percentage points below what was measured; measured number inside the range.
By their numbers in this assay, from the lowest: compounds 1, 2 and 3 (each within the scatter of the next).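

In this assay, among the compounds shown here, the change from 4-fluorophenyl to phenyl gives the first reading at this position (a number 8.1 percentage points higher from compound 2 to compound 3 (within the scatter)). Since that step lies within the scatter, this position tolerates the loss of fluoro without a clear change in the read-out, though only this single replacement has been read. No available evidence bears on this result. As far as these compounds go, what remains open is whether an amine, a carboxylic acid or a longer chain on the same aromatic carbon would move the read-out beyond the scatter.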